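The source may report more compounds than this note shows. Statements on the series, on what has been measured and on what is new or still open speak of the compounds shown alone.

In an ADME assay on HCT-116 cells (Homo sapiens) for cytotoxicity, read by CellTiter-Glo, with a stated time of 72 h (a higher number here means a weaker inhibitor, a lower number a stronger inhibitor), compound 1 `CC1CCN(C2CCN(S(=O)(=O)c3ccccc3Br)CC2)CC1` gives > 5000 nM as a limit and not a number. Compound 3 `Cc1cc(C)c(S(=O)(=O)NC2CCN(C3CCN(C)CC3)CC2)c(C)c1` gives > 5000 nM as a limit too. Compound 2 `Cc1cc(C)c(S(=O)(=O)N2CCC(N3CCCCCC3)CC2)c(C)c1` gives > 5000 nM and so stands only at a limit, with no number of its own. The whole set offers the limit of > 5000 nM in this assay, at which 3 of the 3 values shown sit, and nothing finer. Compound 4 `Cc1cc(C)c(S(=O)(=O)N2CCC(C3OCC(C)CO3)CC2)c(C)c1` departs from compound 2 by a group of 7 heavy atoms (5 carbon, 2 oxygen; one six-membered non-aromatic ring with 2 hetero atoms) in place of a group of 7 heavy atoms (6 carbon, 1 nitrogen; one seven-membered non-aromatic ring with 1 hetero atom), on a saturated ring carbon on a saturated ring carbon of a six-membered non-aromatic ring with 1 nitrogen. Within the data shown here, no measured step gives a size for such a change, so none beyond the scatter is expected in this assay in either direction. The expected step is a step that the limit leaves unreadable from compound 2 to compound 4 and no more than that. This expectation leans on compound 2 and its limit > 5000 nM alone. Compound 4 is estimated at 6000 nM with an expected range from 2500 nM to 15000 nM and will probably be reported as a limit as well.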

Compound 4, half-maximal inhibitory concentration: > 5000 nM
Compound 4 gave a limit, no number; the forecaster's own chance of this, stated with the estimate: 90%; the middle value lies beyond the limit too.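

No step from compound 2 to compound 4 can be read, as both stand only at a limit in this assay: the limit of > 5000 nM in this assay, at which 4 of the 4 values shown sit.

The compounds shown leave open how the half-maximal inhibitory concentrations of these compounds compare in this assay.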